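Chloro to (1-Methyl-1H-tetrazol-5-yl)sulfanyl: an Expected Loss

This account rests on a few compounds, and the source may have more. Where it says the series, first, only, none or still open, it means among the compounds named here.

The measured compounds:
Compound 1 `CCOc1cc2ncnc(Nc3ccc(F)c(Cl)c3)c2cc1OC(=O)CCl`: in a functional assay on NCI-H1975 cells (Homo sapiens) for inhibition, read by MTT assay, with a stated time of 72 h (on this read-out higher numbers stand for weaker inhibition and lower numbers for stronger inhibition), compound 1 gives 60 nM.
Compound 2 `CCOc1cc2ncnc(Nc3ccc(F)c(Cl)c3)c2cc1OC(=O)CSc1ncccn1`: in this assay compound 2 gives 3600 nM.

Compound 1 stands at the lowest of the two numbers; its nearest neighbour is compound 2, reached by the step of a 60-fold higher number from compound 1 to compound 2 (1.78 log units; beyond the scatter), which is a (pyrimidin-2-yl)sulfanyl in place of chloro on a saturated chain carbon bound to a carbonyl carbon.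

Compound 3 `CCOc1cc2ncnc(Nc3ccc(F)c(Cl)c3)c2cc1OC(=O)CSc1nnnn1C` differs from compound 1 by (1-methyl-1H-tetrazol-5-yl)sulfanyl in place of chloro on a saturated chain carbon bound to a carbonyl carbon. Within the data shown here, the only measured step that bears on this change is a 60-fold higher number from compound 1 to compound 2 (1.78 log units; beyond the scatter), where a different aromatic heterocycle was attached through sulfur at the same place and the number rose by a large amount. A step of similar size and direction is therefore expected in this assay for compound 3. Compound 3 is estimated at 2500 nM, with a range of 600 nM to 10000 nM. This estimate means the step of a 42-fold higher number from compound 1 to compound 3 (1.62 log units; beyond the scatter) is expected.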

Compound 3, half-maximal inhibitory concentration: 2100 nM
Estimate against measurement, compound 3: 1.2-fold (0.08 log units) above; the range from low to high includes it.
By their numbers in this assay, from the lowest: compound 1; then compounds 3 and 2 (each within the scatter of the next).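

In this assay, a second aromatic heterocycle attached through sulfur on the saturated chain carbon bound to a carbonyl carbon brings a large loss too: a 35-fold higher number from compound 1 to compound 3 (1.54 log units; beyond the scatter) runs in the same direction as a 60-fold higher number from compound 1 to compound 2 (1.78 log units; beyond the scatter) and shows that this loss is not confined to the pyrimidin-2-yl group. Exchanging the heterocycle on the sulfur gives a 1.7-fold lower number from compound 2 to compound 3 (0.23 log units; within the scatter) and so does not separate 1-methyl-1H-tetrazol-5-yl from pyrimidin-2-yl, which leaves both sulfanyl compounds well apart from the chloro compound 1. No supporting data are available to explain the loss.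

The compounds shown do not settle whether the loss goes with the sulfur link, the aromatic ring on it, or the departure of chloro. As far as these compounds go, how bromo, methylsulfanyl or a morpholin-4-yl amine would read at this place remains open.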